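Shortening a Linker Chain by One Carbon

The source may hold more compounds than are shown below. What is called first, only, known or untested is meant among the compounds shown, and "the series" means these compounds.

Measured so far:
compound 1 `CC(C)(C)[Si](OCc1ccc(=O)[nH]n1)(c1ccccc1)c1ccccc1` — 62600 nM
compound 2 `Cn1nc(CCCO[Si](c2ccccc2)(c2ccccc2)C(C)(C)C)ccc1=O` — > 100000 nM

Of the compounds shown here, two have been tested in a functional assay on aorta (Rattus norvegicus); on this read-out higher numbers stand for weaker inhibition and lower numbers for stronger inhibition. Compound 1 `CC(C)(C)[Si](OCc1ccc(=O)[nH]n1)(c1ccccc1)c1ccccc1` gives 62600 nM in this assay. For compound 2 `Cn1nc(CCCO[Si](c2ccccc2)(c2ccccc2)C(C)(C)C)ccc1=O` the read-out in this assay is a limit of the assay, > 100000 nM, and not a number; it is one of the two values that sit at the limit of > 100000 nM in this assay, at which 1 of the 2 values shown sits. So compound 2 stands at the weak end of everything measured here.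

Compound 3 `Cn1nc(CCO[Si](c2ccccc2)(c2ccccc2)C(C)(C)C)ccc1=O` has not yet been measured. It differs from compound 2 by a group of 8 heavy atoms (5 carbon, 2 nitrogen, 1 oxygen; one six-membered aromatic ring with 2 hetero atoms) in place of a group of 9 heavy atoms (6 carbon, 2 nitrogen, 1 oxygen; one six-membered aromatic ring with 2 hetero atoms), on a saturated chain carbon, two bonds along the chain from an oxygen on an unsaturated carbon — in words, a group of 8 heavy atoms (5 carbon, 2 nitrogen, 1 oxygen; one six-membered aromatic ring with 2 hetero atoms) in place of a group of 9 heavy atoms (6 carbon, 2 nitrogen, 1 oxygen; one six-membered aromatic ring with 2 hetero atoms), on a saturated chain carbon, two bonds along the chain from an oxygen on an unsaturated carbon.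

Among the measured compounds shown here, no step between two measured compounds is available, so the effect of this change cannot be read from the numbers. The expected step in this assay is a number no higher from compound 2 to compound 3 (the limit leaves the size open), no more than the usual scatter in either direction. Compound 3 is therefore expected to give about 100000 nM in this assay, in a range from 30000 nM to 300000 nM, quite possibly again only as a limit.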

Compound 3, half-maximal inhibitory concentration: 47000 nM
Beside the measured number, compound 3's estimate is 2.1-fold (0.33 log units) above it; measured number inside the range.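

In this assay, shortening the chain by one carbon, a group of 8 heavy atoms in place of a group of 9, gives an at least 2.1-fold lower number from compound 2 to compound 3 (0.32 log units; beyond the scatter), so the read-out does respond to a change at this saturated chain carbon. This step gives only a minimum size, because compound 2 sits at a limit of the assay and not at a number: the limit of > 100000 nM in this assay, at which 1 of the 3 values shown sits. Changing the group on the saturated chain carbon bound to an oxygen gives a 1.3-fold lower number from compound 1 to compound 3 (0.12 log units; within the scatter), so no difference can be claimed for that pair.

As far as these compounds go, the true size of the one-carbon effect remains open, and so does how a longer chain would read. From the compounds shown here alone, it is also open whether an amine or a carboxylic acid in place of the silyl ether would keep any activity on this read-out.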